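The compounds below may be only part of what the source reports. "The series", "measured", "known", "first", "only" and "open" are said of these compounds alone.

Measured compounds and their values:
Compound 1 `CNC(=O)c1c(O)c2cccnc2n(-c2ccccc2)c1=O` gives 21%.
Compound 2 `Cc1ccc(NC(=O)c2c(O)c3cccnc3n(-c3ccccc3)c2=O)cc1` gives 2.2%.
Compound 3 `Cc1cccc(NC(=O)c2c(O)c3cccnc3n(-c3ccccc3)c2=O)c1` gives 4.5%.

All three were read in a functional assay on the whole organism for inhibition, with Rattus norvegicus as the target, read by cytopathic effect and paw edema, at a dose of 100 mg/kg by the oral route; a lower number here means less inhibition, a higher number more inhibition at the dose given (going by the name of the read-out). Compound 3 stands second highest of the three numbers; its nearest neighbour is compound 2, within the scatter, and its furthest is compound 1, beyond the scatter. The two aryl amides thus sit together well below the methyl amide.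

Compound 4 `COc1ccccc1NC(=O)c1c(O)c2cccnc2n(-c2ccccc2)c1=O` has not yet been measured. Its difference from compound 3 is 2-methoxyphenyl in place of 3-methylphenyl on an amide-type nitrogen. Among the measured compounds shown here, the steps that bear on this are the two in which an aryl group replaced methyl on the amide-type nitrogen: a number 18.8 percentage points lower from compound 1 to compound 2 (beyond the scatter) and a number 16.5 percentage points lower from compound 1 to compound 3 (beyond the scatter), both modest and beyond the scatter. The step between the two aryl amides themselves, a number 2.3 percentage points higher from compound 2 to compound 3 (within the scatter), lies within the scatter, so exchanging one substituted phenyl for another has so far not moved the number. For the measured compounds named here, no measured step involves a methoxy group, so the effect of that oxygen is unknown here.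

Compound 4 is therefore expected to remain close to compound 3, with a number 0.5 percentage points higher from compound 3 to compound 4 (within the scatter) not beyond the scatter. The estimate for compound 4 is 5%, with a range from 0% to 16%.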

Compound 4, a percentage reported as inhibition, in the whole organism at one dose (the size of the read-out at that dose, not a potency): -10.1%
For compound 4 the middle estimate is 15.1 percentage points above the measured one; the whole stated range lies above it.
By their numbers in this assay, from the lowest: compound 4; then compounds 2 and 3 (each within the scatter of the next); then compound 1.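

In this assay the amide-type nitrogen proves sensitive to the kind of substituted phenyl it carries. The exchange of 4-methylphenyl for 3-methylphenyl stayed within the scatter, whereas 2-methoxyphenyl gives a number 14.6 percentage points lower from compound 3 to compound 4 (beyond the scatter) and a number 12.3 percentage points lower from compound 2 to compound 4 (beyond the scatter), both beyond the scatter, so the aryl amides no longer sit together. Among the compounds shown here, compound 4 reads -10.1%, a negative number that places it lowest of the four, with a number 31.1 percentage points lower from compound 1 to compound 4 (beyond the scatter) as the only large step in the set, and nothing available explains why this exchange moves the number when the earlier one did not.

The three aryl amides leave unresolved whether the methoxy group itself or its place on the phenyl ring accounts for the drop, since the change from 3-methylphenyl to 2-methoxyphenyl alters both at once. The compounds shown also leave open how a phenyl without any substituent, a carboxylic acid or an amine on that phenyl, or a longer chain such as ethyl or butyl on the amide-type nitrogen would read at this dose.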